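Swapping the Oxazole on the Amide Nitrogen for Hydroxyethyl

A few compounds are considered here, and "the series" means these few. Any claim that something is new, unique, unknown or untested is made for them only; others in the source may bear on it.

Compound 1 `Cc1ccc(OCC(=O)N(Cc2cccs2)c2ncco2)cc1`: 0.3 nM
Compound 2 `CCc1ccc(OCC(=O)N(CC)Cc2cccs2)cc1`: 67 nM
Compound 3 `CCN(Cc1ccncc1)C(=O)COc1ccc(C)cc1`: "not active" (no number reported)

In an assay on HEK293 cells for agonist activity at transient receptor potential cation channel subfamily M member 8 (Homo sapiens), read by fluorescence and calcium flux, with a stated time of 15 min (on this read-out higher numbers stand for an effect only at larger amounts of compound and lower numbers for an effect already at smaller amounts), compound 1 gives 0.3 nM, the lowest of the two numbers reported; the nearest is compound 2 at 67 nM, a higher number that lies beyond the usual scatter. Compound 3 is reported in this assay as "not active" (no number reported), with no number given. Compound 4 `Cc1ccc(OCC(=O)N(CCO)Cc2cccs2)cc1` is not yet measured there. It differs from compound 1 in one place: 2-hydroxyethyl in place of 1,3-oxazol-2-yl on an amide-type nitrogen. Compound 2 carries only a saturated group on that nitrogen and sits at 67 nM, so a large upward step in this assay is expected for compound 4, a 200-fold higher number from compound 1 to compound 4 (2.30 log units; beyond the scatter). Compound 4 is therefore estimated at 60 nM, within 10 nM to 500 nM.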

Compound 4, half-maximal effective concentration: 900 nM
Compound 4: the middle estimate sits 15-fold (1.18 log units) below what was measured, and the stated range ends below it.
By their numbers in this assay, from the lowest: compound 1; then compound 2; then compound 4.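

In this assay, placing 2-hydroxyethyl instead of 1,3-oxazol-2-yl on the amide-type nitrogen gives a 3000-fold higher number from compound 1 to compound 4 (3.48 log units; beyond the scatter), the first single-place measure at this position. Replacing the oxazole therefore has a very large effect on the number here, yet compound 4, which has no ring in that place, still gives a number. Nothing available explains the size of this step. From the compounds shown here alone, it remains open whether the rise follows from losing the ring or from gaining the hydroxyl; an ethyl, a 2-methoxyethyl or a phenyl on this nitrogen of compound 1 would help separate the two.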